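This account rests on a few compounds, and the source may have more. Where it says the series, first, only, none or still open, it means among the compounds named here.

Values in an ADME assay on L6 cells (Rattus norvegicus) for cytotoxicity, read by resazurin assay, with a stated time of 72 h; a higher number here means a weaker inhibitor, a lower number a stronger inhibitor:
- compound 1 `O=C(NC(=O)c1ccccc1O)c1ccc(-c2ccccc2)cc1`: > 100 ug/mL (a limit of the assay)
- compound 2 `O=C(NC(=O)c1ccccc1O)c1ccc(OC(F)(F)F)cc1`: 84 ug/mL
- compound 3 `O=C(NC(=O)c1ccccc1O)c1ccc([N+](=O)[O-])cc1`: 53 ug/mL

Compound 3 at 53 ug/mL stands within the scatter of compound 2 at 84 ug/mL. Compound 1 gives only a limit, so it cannot be placed exactly.

Compound 4 `CCCCOc1ccc(C(=O)NC(=O)c2ccccc2O)cc1` carries butoxy in place of nitro on an aromatic carbon, para to a large group (butoxy in place of nitro on an aromatic carbon). Going by the values given here, no measured compound carries butoxy, so the swaps already measured on this carbon are the only guide. The steps of an at least 1.1-fold lower number from compound 1 to compound 2 (0.07 log units; that floor lies within the scatter) and an at least 1.8-fold lower number from compound 1 to compound 3 (0.27 log units; that floor lies within the scatter) are floors only because of the limit of > 100 ug/mL in this assay, at which 1 of the 3 values shown sits. Among the compounds with values here, the one full step is a 1.6-fold lower number from compound 2 to compound 3 (0.20 log units; within the scatter), and it stays within the scatter. On that step, no change beyond the scatter is expected in this assay, and no direction is favoured. The expected step is a 1.0-fold higher number from compound 3 to compound 4 (0.02 log units; within the scatter). For compound 4 the estimated value is 55 ug/mL, with an expected range from 24 ug/mL to 100 ug/mL.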

Compound 4, half-maximal inhibitory concentration: 13 ug/mL
Compound 4: the middle estimate sits 4.2-fold (0.63 log units) above what was measured; the whole stated range lies above it.
By their numbers in this assay, from the lowest: compound 4; then compounds 3 and 2 (each within the scatter of the next). At a limit, above all of these: compound 1.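

In this assay, going by these compounds alone, the group on this aromatic carbon, para to a large group, now moves the number beyond the scatter: a 4.1-fold lower number from compound 3 to compound 4 (0.61 log units; beyond the scatter), and a 6.5-fold lower number from compound 2 to compound 4 (0.81 log units; beyond the scatter), whereas the one full step among the earlier compounds, a 1.6-fold lower number from compound 2 to compound 3 (0.20 log units; within the scatter), gave no such separation. Butoxy thus gives compound 4 the lowest number of the set, and this position is shown to respond to the change of group. The third step, an at least 7.6-fold lower number from compound 1 to compound 4 (0.88 log units; beyond the scatter), is a floor and not a full size: the limit of > 100 ug/mL in this assay, at which 1 of the 4 values shown sits.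

With butoxy as the only alkyl ether shown, it remains open whether the shift follows the chain or the oxygen that links it to the ring. A longer chain such as hexyloxy, a butyl group without that oxygen, or an amine on the same carbon would help separate these readings.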